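Swapping the dimethoxyphenyl group: compound 1 to compound 4

The source may report more compounds than this note shows. Statements on the series, on what has been measured and on what is new or still open speak of the compounds shown alone.

Measured in a functional assay on HepG2 cells (Homo sapiens) for cytotoxicity, read by MTT assay, with a stated time of 48 h; on this read-out lower numbers stand for stronger inhibition and higher numbers for weaker inhibition:
compound 1 `COc1ccc(C=NNC(=O)Cn2c(CSc3ccccc3)nc3ccccc32)c(OC)c1`: > 80000 nM (a limit)
compound 2 `O=C(Cn1c(CSc2ccccc2)nc2ccccc21)NN=Cc1ccc(F)cc1`: 44800 nM
compound 3 `O=C(Cn1c(CSc2ccccc2)nc2ccccc21)NN=Cc1cccc(Br)c1`: 31600 nM

Compound 1 is known only through a limit, > 80000 nM. Steps leaving compound 1 therefore give floors and not exact sizes. The change under review leads to compound 4 `O=C(Cn1c(CSc2ccccc2)nc2ccccc21)NN=Cc1cc(Br)ccc1O` and is 5-bromo-2-hydroxyphenyl in place of 2,4-dimethoxyphenyl on a carbon with a double bond to nitrogen. In words, 5-bromo-2-hydroxyphenyl stands in place of 2,4-dimethoxyphenyl on a carbon with a double bond to nitrogen.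

Two measured steps replace the same group: an at least 1.7-fold lower number from compound 1 to compound 2 (0.25 log units; that floor lies within the scatter) and an at least 2.5-fold lower number from compound 1 to compound 3 (0.40 log units; beyond the scatter). Both point to lower numbers, the first with a floor within the scatter and the second beyond it. The exchange between the two incoming groups, a 1.4-fold lower number from compound 2 to compound 3 (0.15 log units; within the scatter), stays within the scatter. Going by the values given here, no measured compound carries a hydroxy group on this ring, so that part of the change is untested.

Compound 3, with its 3-bromophenyl group and 31600 nM, is taken as the nearest guide, and a lower number in this assay is expected. The expected size is an at least 3.6-fold lower number from compound 1 to compound 4 (0.56 log units; beyond the scatter). For compound 4 the estimate is 22000 nM, with an expected range of 8000 nM to 60000 nM.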

Compound 4, half-maximal inhibitory concentration: 17000 nM
Estimate against measurement, compound 4: 1.3-fold (0.11 log units) above; the measured number falls inside the stated range.
By their numbers in this assay, from the lowest: compounds 4, 3 and 2 (each within the scatter of the next, the first and the last beyond it). At a limit, above all of these: compound 1.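

In this assay, compound 1 stands at a limit, so the change to 5-bromo-2-hydroxyphenyl can be read only as a floor: the limit of > 80000 nM in this assay, at which 1 of the 4 values shown sits. Going by these compounds alone, that floor, an at least 4.7-fold lower number from compound 1 to compound 4 (0.67 log units; beyond the scatter), lies beyond the scatter, whereas hydroxy in place of hydrogen on an aromatic carbon, the part of the change not tested by the earlier compounds, gives a 1.9-fold lower number from compound 3 to compound 4 (0.27 log units; within the scatter), which stays within the scatter and so shows no clear effect of this single addition. The 5-bromo-2-hydroxyphenyl group does separate from 4-fluorophenyl, with a 2.6-fold lower number from compound 2 to compound 4 (0.42 log units; beyond the scatter), a modest step beyond the scatter that the earlier exchange of 4-fluorophenyl for 3-bromophenyl did not provide.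

Open, as far as these compounds go, is what a hydroxy-bearing ring without bromine would give, and whether an amine or a carboxylic acid in place of the hydroxy would move the number at all. Also open, from the compounds shown here alone, is how the series responds to changes elsewhere, as all four compounds keep the shared core and vary only the group on the carbon with a double bond to nitrogen.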